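A few compounds are considered here, and "the series" means these few. Any claim that something is new, unique, unknown or untested is made for them only; others in the source may bear on it.

Three close relatives built on a shared core have been measured in a functional assay on CHO-K1 cells for antagonist activity at C-X-C chemokine receptor type 3 (Homo sapiens), read by FLIPR, with a stated time of 10 min; a lower number here means a stronger inhibitor, a higher number a weaker inhibitor. Compound 1 `Cc1nc(C)n(CC(=O)N2CCN(c3sc(C(F)(F)F)nc3-c3cnc(OC(C)C)nc3)C[C@H]2C)n1` gives 3.4 nM. Compound 2 `Cc1ncc(-c2nc(C(F)(F)F)sc2N2CCN(C(=O)Cn3nc(C)nc3C)[C@H](C)C2)cn1` gives 19 nM. Compound 3 `Cc1nc(C)n(CC(=O)N2CCN(c3sc(C(F)(F)F)nc3-c3cnc(N4CCCC4)nc3)C[C@H]2C)n1` gives 3.5 nM. Among these three numbers compound 3 holds the second highest; its nearest neighbour is compound 1, and that gap lies within the scatter, while compound 2 lies furthest from it. The step of a 5.4-fold lower number from compound 2 to compound 3 (0.73 log units; beyond the scatter) is modest but beyond the scatter, as is a 5.6-fold higher number from compound 1 to compound 2 (0.75 log units; beyond the scatter), whereas a 1.0-fold higher number from compound 1 to compound 3 (0.01 log units; within the scatter) stays within the scatter.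

Compound 4 `COc1ccc(-c2nc(C(F)(F)F)sc2N2CCN(C(=O)Cn3nc(C)nc3C)[C@H](C)C2)cn1` has not yet been measured. It differs from compound 3 in one place: 6-methoxypyridin-3-yl in place of 2-(pyrrolidin-1-yl)pyrimidin-5-yl on an aromatic carbon. The measured steps that bear on this are the ones in which the group on that same carbon of the core was exchanged. There, swapping isopropoxy or pyrrolidin-1-yl for a methyl gave a modestly higher number, while swapping isopropoxy for pyrrolidin-1-yl changed nothing beyond the scatter. The incoming group brings a methoxy, and the ring it sits on is itself altered, so a modest rise in the number is expected, smaller than the step to compound 2. For compound 4 the expected step is a 2.9-fold higher number from compound 3 to compound 4 (0.46 log units; beyond the scatter). Compound 4 is therefore estimated at 10 nM, with a range from 3 nM to 35 nM.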

Compound 4, half-maximal inhibitory concentration: 18 nM
For compound 4 the middle estimate is 1.8-fold (0.26 log units) below the measured one; measured number inside the range.
By their numbers in this assay, from the lowest: compounds 1 and 3 (each within the scatter of the next); then compounds 4 and 2 (each within the scatter of the next).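

Among these compounds, until now, the only exchange at this aromatic carbon that gave a higher number in this assay was the one to 2-methylpyrimidin-5-yl. Compound 4 shows that this is not tied to that group alone, since a different ring bearing a methoxy gives a 5.1-fold higher number from compound 3 to compound 4 (0.71 log units; beyond the scatter) and a 5.3-fold higher number from compound 1 to compound 4 (0.72 log units; beyond the scatter) as well. Its step from the methyl compound, a 1.1-fold lower number from compound 2 to compound 4 (0.02 log units; within the scatter), stays within the scatter, so two unlike groups sit at one level here, while 2-isopropoxypyrimidin-5-yl and 2-(pyrrolidin-1-yl)pyrimidin-5-yl sit together at a lower number, and nothing available explains this split.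

Compound 4 changes the ring and the group on it at once, so these compounds cannot tell whether the pyridine ring, the methoxy or the two together account for its step; 2-methoxypyrimidin-5-yl and 6-isopropoxypyridin-3-yl would be the pieces that pull them apart. As far as these compounds go, how far this carbon tolerates something quite different on that ring, such as a primary amine or a carboxylic acid, also stays open.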